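This account rests on a few compounds, and the source may have more. Where it says the series, first, only, none or still open, it means among the compounds named here.

Measured in a functional assay on NCI-H1581 cells (Homo sapiens) for antiproliferative activity, read by CCK-8 assay, with a stated time of 72 h; on this read-out higher numbers stand for weaker inhibition and lower numbers for stronger inhibition:
- compound 1 `COc1cc(OC)c(Cl)c(-c2ccc3c(NC(=O)c4ccc(N5CCN(C(C)=O)CC5)cc4)n[nH]c3n2)c1Cl` gives 43.3 nM
- compound 2 `COc1cc(OC)c(Cl)c(-c2ccc3c(NC(=O)c4ccc(N(C)C)cc4)n[nH]c3n2)c1Cl` gives 294 nM

Compound 2 has the higher number of the two (294 nM), so it is the weaker inhibitor. Compound 3 `COc1cc(OC)c(Cl)c(-c2ccc3c(NC(=O)c4ccc(N5CCNCC5)cc4)n[nH]c3n2)c1Cl` has piperazin-1-yl in place of dimethylamino on an aromatic carbon. Among the measured compounds shown here, one measured step bears on this change, a 6.8-fold higher number from compound 1 to compound 2 (0.83 log units; beyond the scatter), where dimethylamino replaced 4-acetylpiperazin-1-yl. For the measured compounds named here, compound 3 also carries a piperazine ring, but without the acetyl group, and no measurement yet isolates that group. A similar or somewhat smaller step towards a lower number is therefore expected in this assay. The estimated change is a 4.2-fold lower number from compound 2 to compound 3 (0.62 log units; beyond the scatter). Compound 3 is expected near 70 nM, within an estimated range of 20 nM to 250 nM.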

Compound 3, half-maximal inhibitory concentration: 1.4 nM
Compound 3: middle estimate off by 50-fold (1.70 log units), on the high side; measured number outside the range, below it.
By their numbers in this assay, from the lowest: compound 3; then compound 1; then compound 2.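

In this assay, piperazin-1-yl on this aromatic carbon goes far beyond dimethylamino, with a 210-fold lower number from compound 2 to compound 3 (2.32 log units; beyond the scatter). Taking the acetyl off the ring nitrogen also counts heavily, with a 31-fold lower number from compound 1 to compound 3 (1.49 log units; beyond the scatter). Among these compounds, then, the piperazine ring alone does not give the lowest number: the ring with its nitrogen left free does.

As far as these compounds go, whether a methyl group on that nitrogen, or a morpholine ring in place of the piperazine, would keep so low a number remains open. No measurement here gives a reason for these steps.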